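The compounds below may be only part of what the source reports. "The series", "measured", "known", "first", "only" and "open" are said of these compounds alone.

Measured so far in a functional assay on MCF7 cells (Homo sapiens) for antiproliferative activity, read by MTT assay, with a stated time of 24 h; on this read-out higher numbers stand for weaker inhibition and lower numbers for stronger inhibition:

Compound 1 `c1ccc(-c2noc(-c3ccncc3)n2)cc1`: > 1000000 nM
Compound 2 `COc1ccc(-c2noc(-c3ccccc3)n2)cc1OC1CCCC1`: > 1000000 nM

Neither entry is a true number. Compound 1 gives > 1000000 nM, and this is a limit of the assay. Compound 2 gives > 1000000 nM in this assay, and this too is only a limit. Compound 2 therefore stands at the limit of > 1000000 nM in this assay, at which 2 of the 2 values shown sit, and its real position cannot be read any more closely.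

The next compound, compound 3 `COc1ccc(-c2noc(-c3ccc(Cl)cc3)n2)cc1OC1CCCC1`, keeps the frame of compound 2 and changes it in one place. A chloro group takes the place of hydrogen on an aromatic carbon, turning phenyl into 4-chlorophenyl: chloro in place of hydrogen on an aromatic carbon. Going by the values given here, no measured pair shows what such a change does here, so the expectation is a cautious one. No shift beyond the usual scatter is expected in this assay, and compound 3 may well stay at the same limit. The expected change is an at least 1.2-fold lower number from compound 2 to compound 3 (0.09 log units; that floor lies within the scatter). This expectation rests on compound 2, with its > 1000000 nM. For compound 3 the estimated value is 800000 nM, with an expected range from 200000 nM to 1500000 nM.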

Compound 3, half-maximal inhibitory concentration: 174000 nM
The estimate for compound 3 lay 4.6-fold (0.66 log units) above the measured number; measured number below the stated range.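

In this assay, compound 3 is the first of the compounds shown to give a true number rather than a limit, so this single change is the first to bring the read-out into the range the assay can measure. Chloro in place of hydrogen on an aromatic carbon, para to a large group, brings an at least 5.7-fold lower number from compound 2 to compound 3 (0.75 log units; beyond the scatter), which shows that this place on the frame of compound 2 can respond to a substituent. The size of the step remains a floor and not a full measure, since compound 2 has no true number of its own: the limit of > 1000000 nM in this assay, at which 2 of the 3 values shown sit.

The compounds shown leave open whether the effect belongs to chloro itself or whether another group in the same place, such as fluoro, methoxy, an amine or a carboxylic acid, would lower the number as far or further. They also leave open whether chloro would bring a similar step elsewhere on this ring, or on the frame of compound 1.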